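A methoxy group added to the butyl chain

The source may report more compounds than this note shows. Statements on the series, on what has been measured and on what is new or still open speak of the compounds shown alone.

Three compounds share one core, a benzene ring carrying a butylamino chain and a sulfonamide. Compound 1 `CCCCNc1ccc([N+](=O)[O-])cc1S(=O)(=O)N(C)C` bears a nitro group and a dimethylated sulfonamide; in an assay on HEK293 cells for inhibition of solute carrier family 12 member 2 (Homo sapiens), read by fluorescence, with a stated time of 30 min, tested at 100 uM (a lower number here means a weaker effect, a higher number a stronger effect of the compound at the concentration tested), compound 1 gives 15.2%. Compound 2 `CCCCNc1ccc(C(=O)O)cc1S(=O)(=O)NC` carries a carboxy group and a sulfonamide with one methyl; compound 2 gives 6.2%. Compound 3 `CCCCNc1ccc(C(=O)O)cc1S(=O)(=O)N(C)C` combines the carboxy group with the dimethylated sulfonamide; compound 3 gives 15.6%. Compound 3 holds the highest of the three numbers, but the steps to it are small: a number 0.4 percentage points higher from compound 1 to compound 3 (within the scatter) and a number 9.4 percentage points higher from compound 2 to compound 3 (within the scatter). Neither change moves the read-out beyond the scatter.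

Compound 4 `COCCCCNc1ccc(C(=O)O)cc1S(=O)(=O)N(C)C` differs from compound 3 in one place: methoxy in place of hydrogen on a saturated chain carbon, four bonds along the chain from a nitrogen on an aromatic ring. For the measured compounds named here, no measured step alters the butyl chain, so nothing measured speaks for a shift in either direction, and the two steps that exist lie within the scatter. The estimate for compound 4 is therefore a step of a number 1.6 percentage points lower from compound 3 to compound 4 (within the scatter), expected to stay near the value of compound 3. Compound 4 is expected to give about 14%, within a range from 4% to 26%.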

Compound 4, a percentage reported as inhibition, at one concentration (the size of the read-out at that concentration, not a potency): 5.2%
Compound 4: middle estimate off by 8.8 percentage points, on the high side; low and high end bracket the measured number.
By their numbers in this assay, from the lowest: compounds 4, 2, 1 and 3 (each within the scatter of the next, the first and the last beyond it).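

Methoxy in place of hydrogen on a saturated chain carbon, four bonds along the chain from a nitrogen on an aromatic ring, gives a number 10.4 percentage points lower from compound 3 to compound 4 (beyond the scatter) in this assay, and this is the only step in the set that goes beyond the scatter. The butyl chain is therefore a place where a change can move the read-out, whereas the two earlier steps, one from nitro to carboxy and one adding a methyl on the sulfonamide nitrogen, stayed within the scatter. Nothing in the data gives a reason for this lower number, so the step stands as an observation without an explanation.

The compounds shown leave open whether the lower number goes with the oxygen of the methoxy group or simply with the extra length, a question that a plain pentyl or hexyl chain in place of 4-methoxybutyl could help to settle. They also leave open how a hydroxy group or an amine at the same place on the chain would read, and whether methoxy has a similar effect when the core carries nitro instead of carboxy.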